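This account rests on a few compounds, and the source may have more. Where it says the series, first, only, none or still open, it means among the compounds named here.

Working notes on the cytotoxicity series.

Compound 1 `CNC(=O)Nc1c(C)c(C(OC(C)(C)C)C(=O)O)c(-c2ccc(C)c(C)c2)c(C)c1-c1ccc(C)c(C)c1` is measured in an ADME assay on MT4 cells (Homo sapiens) for cytotoxicity, read by MTT assay, with a stated time of 4 days (on this read-out lower numbers stand for higher toxicity in this test and higher numbers for lower toxicity in this test), and gives 20000 nM. Compound 2 `Cc1ccc(-c2c(C)c(-c3ccccc3)c(C(OC(C)(C)C)C(=O)O)c(C)c2NS(C)(=O)=O)cc1C` gives only a limit in this assay, namely > 50000 nM. Compound 3 `Cc1ccc(-c2c(C)c(-c3ccc4c(c3)CCO4)c(C(OC(C)(C)C)C(=O)O)c(C)c2NS(C)(=O)=O)cc1C` gives 38000 nM in this assay. Among the two actual numbers compound 1 sits lowest, but compound 3 lies within the scatter of it, so no order between them can be read. Within the data shown here, the single step measured so far, an at least 1.3-fold lower number from compound 2 to compound 3 (0.11 log units; that floor lies within the scatter), concerns a different position of the core and starts from a limit (the limit of > 50000 nM in this assay, at which 1 of the 3 values shown sits), so it carries little weight.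

Compound 4 `CCNC(=O)Nc1c(C)c(C(OC(C)(C)C)C(=O)O)c(-c2ccc(C)c(C)c2)c(C)c1-c1ccc(C)c(C)c1` differs from compound 1 by methyl in place of hydrogen on a saturated chain carbon bound to an amide-type nitrogen. Among the measured compounds shown here, no measured step touches this position of the core, and the one step available does not rise beyond the scatter, so the change from compound 1 to compound 4 is expected to stay within the scatter, without a direction beyond it: the expected step is no change at the digits printed from compound 1 to compound 4 (within the scatter). Compound 4 is accordingly estimated at 20000 nM in this assay, within a range from 10000 nM to 45000 nM.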

Compound 4, half-maximal cytotoxic concentration: 15000 nM
Beside the measured number, compound 4's estimate is 1.3-fold (0.12 log units) above it; measured number inside the range.
By their numbers in this assay, from the lowest: compounds 4, 1 and 3 (each within the scatter of the next, the first and the last beyond it). At a limit, above all of these: compound 2.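

In this assay, the first step read at this position, a 1.3-fold lower number from compound 1 to compound 4 (0.12 log units; within the scatter), shows that methyl in place of hydrogen on a saturated chain carbon bound to an amide-type nitrogen leaves the number within the scatter. Methylcarbamoyl and ethylcarbamoyl therefore cannot be told apart in this test, a reading the earlier compounds could not give, as none of their steps touched this place. This rests on a single pair, and nothing measured here gives a reason for the step.

The compounds shown leave open whether a longer chain such as propyl, a cyclopropyl ring or an amine in place of ethyl would carry the number beyond the scatter. From the compounds shown here alone, whether the same change would read alike on the core of compound 3 also stays open.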